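The source may report more compounds than this note shows. Statements on the series, on what has been measured and on what is new or still open speak of the compounds shown alone.

Compound 1 `COc1ccc(Nc2ncc(C(F)(F)F)c(N3Cc4cccc(N(C)S(C)(=O)=O)c4C3)n2)cc1C(F)(F)F` gives > 30000 nM in a functional assay on HepG2 cells (Homo sapiens) for antiproliferative activity, read by spectrophotometry, with a stated time of 2 days; on this read-out higher numbers stand for weaker inhibition of growth and lower numbers for stronger inhibition of growth; this is a limit of the assay, not a number. Compound 2 `Cc1cc(C)cc(Nc2ncc(C(F)(F)F)c(N3Cc4cccc(N(C)S(C)(=O)=O)c4C3)n2)c1` likewise gives > 30000 nM in this assay, again only a limit. For the measured compounds named here, compound 3 `Cc1ccc(Nc2ncc(C(F)(F)F)c(N3Cc4cccc(N(C)S(C)(=O)=O)c4C3)n2)c(C)c1` gives 19100 nM in this assay, the one value among the three that is a measured number.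

Compound 1 therefore stands at the limit of this assay, where (the limit of > 30000 nM in this assay, at which 2 of the 3 values shown sit). Going by the values given here, the step that the two limits leave unreadable from compound 1 to compound 2 cannot be read, and the steps of an at least 1.5-fold lower number from compound 1 to compound 3 (0.19 log units; that floor lies within the scatter) and an at least 1.5-fold lower number from compound 2 to compound 3 (0.19 log units; that floor lies within the scatter) are floors that themselves lie within the scatter, so none of the measured steps shows a change that can be trusted.

Compound 4 `COc1cc(Nc2ncc(C(F)(F)F)c(N3Cc4cccc(N(C)S(C)(=O)=O)c4C3)n2)cc(C(F)(F)F)c1` keeps the same atoms as compound 1 but joins them differently: 3-methoxy-5-(trifluoromethyl)phenyl in place of 4-methoxy-3-(trifluoromethyl)phenyl on a nitrogen on an aromatic ring. Among the compounds with values here, no measured step concerns such a rearrangement within the same group, and the steps that do exist are either unreadable or within the scatter. The step of a number no higher from compound 1 to compound 4 (the limit leaves the size open) is thus expected to be none beyond the scatter, with compound 4 most likely remaining at or near the limit. For compound 4 the estimate is 30000 nM, with a range from 12000 nM to 80000 nM.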

Compound 4, concentration for 50% growth inhibition: 22100 nM
Estimate against measurement, compound 4: 1.4-fold (0.13 log units) above, within the range that was stated.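

In this assay compound 4 is the first compound shown with methoxy and trifluoromethyl on the phenyl ring that returns a measured number rather than a limit, which gives this place on a nitrogen on an aromatic ring its second readable value. For the compounds shown here, that number cannot be told apart from the one for compound 3, as a 1.2-fold higher number from compound 3 to compound 4 (0.06 log units; within the scatter) shows, and 3-methoxy-5-(trifluoromethyl)phenyl and 2,4-dimethylphenyl thus stand level here. The steps of an at least 1.3-fold lower number from compound 1 to compound 4 (0.13 log units; that floor lies within the scatter) and an at least 1.3-fold lower number from compound 2 to compound 4 (0.13 log units; that floor lies within the scatter) are only floors, and the true size of the rearrangement from 4-methoxy-3-(trifluoromethyl)phenyl cannot be read, nor can any step that ends on a limit at both sides: the limit of > 30000 nM in this assay, at which 2 of the 4 values shown sit.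

The compounds shown leave open whether any group at this place can give a step beyond the scatter, since they carry only methyl, methoxy and trifluoromethyl on the phenyl ring. Going by these compounds, how a phenyl ring bearing an amine or a carboxylic acid would read in this assay also remains open, as does the effect of a longer chain in place of the methoxy.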